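Swapping Methoxy for Methylsulfanyl on Two Related Cores

The source may report more compounds than this note shows. Statements on the series, on what has been measured and on what is new or still open speak of the compounds shown alone.

Compound 1 `CSc1ccc(CNc2nc(SC)nc3ncccc23)cc1` and compound 2 `COc1ccc(CNc2nc(SC)nc3ncccc23)cc1` share one core and differ only in the group on the outer ring. In an ADME assay on BEAS-2B cells (Homo sapiens) for cytotoxicity, read by MTT assay, with a stated time of 72 h (a lower number here means a stronger inhibitor of growth, a higher number a weaker inhibitor of growth), compound 1 gives 3770 nM. Compound 2 reaches only > 100000 nM, which is a limit of the assay rather than a number; it stands at the limit of > 100000 nM in this assay, at which 1 of the 3 values shown sits. The change methylsulfanyl in place of methoxy on an aromatic carbon thus made an at least 26-fold lower number from compound 2 to compound 1 (1.42 log units; beyond the scatter). Compound 3 `COc1ccc(CNc2nc(SC)nc3ccccc23)cc1` carries the methoxy group on a second core; the difference between the two cores is not broken down here. In this assay compound 3 gives 96200 nM. Compound 4 `CSc1ccc(CNc2nc(SC)nc3ccccc23)cc1` has not yet been measured and arises from compound 3 through the same change, (methylsulfanyl in place of methoxy on an aromatic carbon). Resting on the earlier at least 26-fold lower number from compound 2 to compound 1 (1.42 log units; beyond the scatter), the expected step is a 21-fold lower number from compound 3 to compound 4 (1.33 log units; beyond the scatter). Compound 4 is accordingly estimated at 4500 nM.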

Compound 4, concentration for total growth inhibition: 59100 nM
The estimate for compound 4 lay 13-fold (1.12 log units) below the measured number; measured number outside the range, above it.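

In this assay, methylsulfanyl in place of methoxy gave a 1.6-fold lower number from compound 3 to compound 4 (0.21 log units; within the scatter), so on this core the change made no clear difference. The effect of the change therefore did not carry over from one core to the other at the same size: the same change on two cores in this assay, an at least 26-fold lower number (1.42 log units; beyond the scatter) from compound 2 to compound 1 and a 1.6-fold lower number (0.21 log units; within the scatter) from compound 3 to compound 4, at least 16-fold (1.21 log units) apart, beyond the scatter of two such steps

Compound 2 gives > 100000 nM, which is a limit of the assay and not a number, and the two pairs show that the core matters without showing which part of it does.

Going by these compounds, it remains open whether the same split between cores would appear with other groups on the outer ring, such as ethoxy or a dimethylamino group. On these data alone, how the change behaves on any further core also remains open.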